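From compound 3 to compound 4: one chain extension

The compounds below may be only part of what the source reports. "The series", "measured", "known", "first", "only" and "open" are said of these compounds alone.

Measured in a functional assay on HEL cells (Homo sapiens); a lower number here means that less compound is tolerated, a higher number that more compound is tolerated:
- compound 1 `COC(=O)NC1=CS(=O)(=O)O[C@@]12[C@@H](CO[Si](C)(C)C(C)(C)C)O[C@@H](n1cc(C)c(=O)n(C)c1=O)[C@@H]2O[Si](C)(C)C(C)(C)C` – > 200000 nM (a limit)
- compound 2 `COC(=O)CC(=O)NC1=CS(=O)(=O)O[C@@]12[C@@H](CO[Si](C)(C)C(C)(C)C)O[C@@H](n1cc(C)c(=O)n(C)c1=O)[C@@H]2O[Si](C)(C)C(C)(C)C` – 29000 nM
- compound 3 `Cc1cn([C@@H]2O[C@H](CO[Si](C)(C)C(C)(C)C)[C@@]3(OS(=O)(=O)C=C3NCC(=O)OCc3ccccc3)[C@H]2O[Si](C)(C)C(C)(C)C)c(=O)n(C)c1=O` – > 200000 nM (a limit)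

In this assay compound 3 gives > 200000 nM, which is a limit and not a number. The series shows (the limit of > 200000 nM in this assay, at which 2 of the 3 values shown sit), so compound 3 offers no exact starting point.

Compound 4 `Cc1cn([C@@H]2O[C@H](CO[Si](C)(C)C(C)(C)C)[C@@]3(OS(=O)(=O)C=C3NCCC(=O)OCc3ccccc3)[C@H]2O[Si](C)(C)C(C)(C)C)c(=O)n(C)c1=O` differs from compound 3 by (benzyloxycarbonyl)methyl in place of benzyloxycarbonyl on a saturated chain carbon bound to an amine nitrogen. The change is (benzyloxycarbonyl)methyl in place of benzyloxycarbonyl on a saturated chain carbon bound to an amine nitrogen, or (benzyloxycarbonyl)methyl to 2-(benzyloxycarbonyl)ethyl when cut one bond further out.

Going by the values given here, no measured step makes this same change. The nearest ones alter the group on the amine nitrogen: an at least 6.8-fold lower number from compound 1 to compound 2 (0.83 log units; beyond the scatter), and an at least 6.8-fold higher number from compound 2 to compound 3 (0.83 log units; beyond the scatter). Among the compounds with values here, both readable steps involve compound 2, the only compound with a number, at 29000 nM. The remaining step, a step that the two limits leave unreadable from compound 1 to compound 3, gives no size.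

With nothing closer to go on, no step beyond the scatter is expected in this assay, and a second result at the limit is likely. The expected step is a number no higher from compound 3 to compound 4 (the limit leaves the size open). The estimate for compound 4 is 200000 nM, with an expected range of 70000 nM to 400000 nM.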

Compound 4, half-maximal cytotoxic concentration: 200000 nM
Compound 4: the middle estimate sits on the measured number at the digits printed; measured number inside the range.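

In this assay, going by these compounds alone, compound 4 gives 200000 nM, the first exact number for a benzyl ester chain on the amine nitrogen. This allows a direct size for one step in the series: a 6.9-fold higher number from compound 2 to compound 4 (0.84 log units; beyond the scatter). Compound 3 gives > 200000 nM, which is a limit. The extension from (benzyloxycarbonyl)methyl to 2-(benzyloxycarbonyl)ethyl therefore has no readable size: a number no higher from compound 3 to compound 4 (the limit leaves the size open). The same holds for the other step that starts at a limit: a number no higher from compound 1 to compound 4 (the limit leaves the size open). Compound 2 remains the only compound with a clearly lower number, and much of the series still stands at a limit: the limit of > 200000 nM in this assay, at which 2 of the 4 values shown sit.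

From the compounds shown here alone, whether a longer chain on the amine nitrogen, or a carboxylic acid in place of the benzyl ester, would shift the number remains open. The compounds shown also leave the amide carbonyl of compound 2 and its methyl ester unseparated, and a benzyl ester on the same amide chain would be the closest test of which part goes with the lower number.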